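Removing the last methyl from the thiosemicarbazone nitrogen

The source may report more compounds than this note shows. Statements on the series, on what has been measured and on what is new or still open speak of the compounds shown alone.

Three compounds share one core and are compared in a functional assay on MIA PaCa-2 cells (Homo sapiens) for cytotoxicity, read by luminescence, with a stated time of 72 h, in the presence of a further agent that is not named here; on this read-out higher numbers stand for weaker inhibition and lower numbers for stronger inhibition. Compound 1 `CNc1c(F)ccc2c(C=NNC(=S)N(C)C)nccc12` gives 38.4 nM, compound 3 `CN(C)C(=S)NN=Cc1nccc2cc(F)ccc12` gives 21.6 nM, and compound 2 `CNC(=S)N/N=C/c1nccc2cc(F)ccc12` gives 233 nM, the highest of the three numbers and beyond the scatter from both. Among the measured compounds shown here, the only step measured in one place, a 1.8-fold lower number from compound 1 to compound 3 (0.25 log units; within the scatter), concerns a group on an aromatic carbon and lies within the scatter.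

Compound 4 `NC(=S)N/N=C/c1nccc2cc(F)ccc12` differs from compound 2 by hydrogen in place of methyl on an amide-type nitrogen. For the measured compounds named here, no measured step touches this nitrogen, so nothing here tells directly how this assay answers to it; the numbers for compound 2 and compound 3 are the only hint that the substitution of this nitrogen matters. The step in this assay from compound 2 to compound 4 is therefore estimated as a 2.6-fold higher number from compound 2 to compound 4 (0.41 log units; beyond the scatter), an expected increase with wide uncertainty. Compound 4 is expected to give about 600 nM, most likely between 150 nM and 2500 nM.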

Compound 4, half-maximal inhibitory concentration: 2040 nM
For compound 4 the middle estimate is 3.4-fold (0.53 log units) below the measured one; low and high end bracket the measured number.
By their numbers in this assay, from the lowest: compounds 3 and 1 (each within the scatter of the next); then compound 2; then compound 4.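

Among the compounds shown here, the step puts a direct measure on this nitrogen for the first time: in this assay there is an 8.8-fold higher number from compound 2 to compound 4 (0.94 log units; beyond the scatter) when methylamino gives way to amino, which means clearly weaker inhibition once this last methyl is gone. Across compound 3 (21.6 nM), compound 2 (233 nM) and compound 4 (2040 nM), the number rises each time a methyl leaves this nitrogen, and none of these three compounds goes against that order. Nothing available explains why this nitrogen responds so strongly to the loss of a methyl.

Going by these compounds, it remains open whether a longer chain such as ethyl, or a cyclopropyl ring, on this nitrogen would hold the number low or lower it further. On these data alone, it is also open whether this change would have the same size with the methylamino group on the aromatic carbon, as carried by compound 1.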